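Phenyl in place of pentyl on the carbonyl oxygen

The source may report more compounds than this note shows. Statements on the series, on what has been measured and on what is new or still open speak of the compounds shown alone.

Compound 2 `CCCCCOC(=O)C(=O)Nc1cccccc1=O` gives 12% in a functional assay on the whole organism (strain Sprague-Dawley CD) for inhibition, with Rattus norvegicus as the target, read by paw edema, at a dose of 30 mg/kg by the oral route (a lower number here means a weaker effect, a higher number a stronger effect of the compound at the dose given), and stands lowest of the two single numbers in the series. Compound 1 `CCOC(=O)C(=O)Nc1cccccc1=O` gives 79% in this assay, and the step from there is a number 67 percentage points lower from compound 1 to compound 2 (beyond the scatter), a large drop that accompanies a longer chain on the oxygen next to the carbonyl group. Compound 3 `O=C(O)C(=O)Nc1cccccc1=O` has several entries in this assay, 38%; 53%; 32% (3 entries), and the spread of these repeats the several entries of compound 3 in this assay, 38%; 53%; 32% (3 entries) shows how far single numbers in this assay can wander. Compound 4 `O=C(Nc1cccccc1=O)C(=O)Oc1ccccc1` is not yet measured in this assay. It differs from compound 2 by phenyl in place of pentyl on an oxygen next to a carbonyl group. Among the measured compounds shown here, the only measured step touching the same oxygen is a number 67 percentage points lower from compound 1 to compound 2 (beyond the scatter); it shows that what sits there moves the read-out a great deal, but no measured pair exchanges a chain for a ring, so the direction is uncertain. An estimate for compound 4 in this assay is 35%, between 5% and 70%. The step of a number 23 percentage points higher from compound 2 to compound 4 (beyond the scatter) is thus expected to be modest and upward, with wide uncertainty.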

Compound 4, a percentage reported as inhibition, in the whole organism at one dose (the size of the read-out at that dose, not a potency): 31%
Beside the measured number, compound 4's estimate is 4 percentage points above it; low and high end bracket the measured number.
By their numbers in this assay, from the lowest: compound 2; then compound 4; then compound 1.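

With phenyl on an oxygen next to a carbonyl group, the series gains its first exchange of a chain for a ring in this assay: the read-out is a number 19 percentage points higher from compound 2 to compound 4 (beyond the scatter), yet it is also a number 48 percentage points lower from compound 1 to compound 4 (beyond the scatter). Phenyl therefore recovers only part of what pentyl loses, and the ring does not return the read-out to the level of the ethyl compound. The heavy-atom count alone does not set the order, since compound 4 carries more heavy atoms on this oxygen than compound 2 and still stands above it, while single numbers in this series need reading with care, as repeats show: the several entries of compound 3 in this assay, 38%; 53%; 32% (3 entries)

Open, going by these compounds, is whether methyl, isopropyl or benzyl on this oxygen would stay near the level of compound 1. Also open, on these data alone, is whether a substituted phenyl, such as methoxyphenyl, would move the level of compound 4.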